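The source may hold more compounds than are shown below. What is called first, only, known or untested is meant among the compounds shown, and "the series" means these compounds.

Compounds measured so far:

Compound 1 `COc1ccc(-n2cc(CN3C(=O)C[C@@H]4CC[C@@]3(C)C4(C)C)nn2)cc1` — 480 nM
Compound 2 `CC1(C)[C@H]2CC[C@]1(C)N(Cc1cn(-c3ccccc3Br)nn1)C(=O)C2` — 500 nM
Compound 3 `CC1(C)[C@H]2CC[C@]1(C)N(Cc1cn(-c3ccccc3F)nn1)C(=O)C2` — 300 nM

All three share the same core and differ only in the aromatic group carried on an aromatic nitrogen. In a functional assay on SGC-7901 cells (Homo sapiens) for inhibition, read by MTT assay, with a stated time of 24 h (on this read-out lower numbers stand for stronger inhibition and higher numbers for weaker inhibition), compound 1 gives 480 nM, the second highest of the three numbers; its nearest neighbour is compound 2 and its furthest is compound 3, yet both gaps stay within the scatter, so none of the three can be called stronger or weaker than another.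

Compound 4 `CC1(C)[C@H]2CC[C@]1(C)N(Cc1cn(-c3ccc(O)cc3)nn1)C(=O)C2` is the next step from compound 1. The change is hydrogen in place of methyl on an oxygen on an aromatic ring; cut one bond further out it reads 4-methoxyphenyl to 4-hydroxyphenyl.

Among the compounds with values here, none of the measured steps removes the methyl from this oxygen. The steps that touch the same region, a 1.0-fold higher number from compound 1 to compound 2 (0.02 log units; within the scatter) and a 1.6-fold lower number from compound 1 to compound 3 (0.20 log units; within the scatter), swap the whole 4-methoxyphenyl for 2-bromophenyl or 2-fluorophenyl and each stays within the scatter; so does a 1.7-fold lower number from compound 2 to compound 3 (0.22 log units; within the scatter). Since even these larger swaps move the number little, a small change at the oxygen is expected to give no step beyond the scatter, no change at the digits printed from compound 1 to compound 4 (within the scatter). Compound 4 is therefore estimated at 480 nM, with a range of 200 nM to 1100 nM.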

Compound 4, half-maximal inhibitory concentration: 330 nM
Beside the measured number, compound 4's estimate is 1.5-fold (0.16 log units) above it, and the stated range covers the measured number.
By their numbers in this assay, from the lowest: compounds 3, 4, 1 and 2 (each within the scatter of the next).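

In this assay the methyl on this oxygen comes off with a 1.5-fold lower number from compound 1 to compound 4 (0.16 log units; within the scatter) and this is the first step shown that changes the oxygen itself rather than swapping the whole aromatic group. The step shows that a free hydroxy and a methoxy at this position cannot be told apart in this cell read-out, so the methyl is not needed to keep the number in the range of the other compounds. The 4-hydroxyphenyl group also reads alike with the two halogen-bearing rings, with a 1.1-fold higher number from compound 3 to compound 4 (0.04 log units; within the scatter) and with a 1.5-fold lower number from compound 2 to compound 4 (0.18 log units; within the scatter) so all four aromatic groups on this nitrogen fall within the scatter of one another, and no measured data here speak to why the number holds at this oxygen.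

Still open, on these data alone, is whether a longer chain on this oxygen, such as propyl, or an amine or a carboxylic acid in place of the hydroxy would give a step beyond the scatter. As far as these compounds go, all four compounds also keep the same core, so what a change there would do remains unknown.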